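A few compounds are considered here, and "the series" means these few. Any claim that something is new, unique, unknown or untested is made for them only; others in the source may bear on it.

Compound 1 `CC(=O)N(c1nc(C)cs1)N(C(C)=O)S(=O)(=O)c1ccc(C)cc1` gives 7360 nM in a functional assay on HepG2 cells (Homo sapiens) for inhibition, read by XTT assay, with a stated time of 72 h; on this read-out lower numbers stand for stronger inhibition and higher numbers for weaker inhibition. Compound 2 `CC(=O)N(c1nc(CCl)cs1)N(C(C)=O)S(=O)(=O)c1ccc(C)cc1` gives only a limit in this assay, > 62300 nM. Compound 3 `CC(=O)N(c1nc(-c2ccccc2)cs1)N(C(C)=O)S(=O)(=O)c1ccc(C)cc1` likewise gives only a limit, > 58200 nM.

Compound 3 therefore stands at a limit of this assay, not at a number. Compound 4 `CCOC(=O)Cc1csc(N(C(C)=O)N(C(C)=O)S(=O)(=O)c2ccc(C)cc2)n1` differs from it in one place: (ethoxycarbonyl)methyl in place of phenyl on an aromatic carbon. Among the measured compounds shown here, no measured step swaps these two groups directly. The step of an at least 7.9-fold higher number from compound 1 to compound 3 (0.89 log units; beyond the scatter) shows that phenyl in place of methyl weakened inhibition at least modestly, and the step of an at least 8.4-fold higher number from compound 1 to compound 2 (0.92 log units; beyond the scatter) shows a similar weakening for chloromethyl, while the step that the two limits leave unreadable from compound 2 to compound 3 cannot be read between two limits. Both compounds carrying something other than methyl at this place give limits, so compound 4 is expected to stay weak as well. Compound 4 is estimated at 40000 nM (range 8000 nM to 200000 nM), an expected step of an at least 1.4-fold lower number from compound 3 to compound 4 (0.16 log units; that floor lies within the scatter).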

Compound 4, half-maximal inhibitory concentration: 11000 nM
Estimate against measurement, compound 4: 3.6-fold (0.56 log units) above; measured number inside the range.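

Unlike chloromethyl and phenyl, (ethoxycarbonyl)methyl at this position keeps inhibition well clear of the assay limits, with an at least 5.2-fold lower number from compound 3 to compound 4 (0.72 log units; beyond the scatter) and an at least 5.6-fold lower number from compound 2 to compound 4 (0.75 log units; beyond the scatter). Compared with methyl, it gives a 1.5-fold higher number from compound 1 to compound 4 (0.17 log units; within the scatter), so replacing methyl at this position does not always weaken inhibition. Compound 3 stands at a limit, so the step from it gives only a minimum size: the limit of > 58200 nM in this assay, at which 1 of the 4 values shown sits.

On these data alone, it remains open whether the ethoxycarbonyl group itself matters or any chain of this length would do. A carboxylic acid or a longer chain at this position could help separate the two.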